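Chloro for amino on the shared core of compound 2

The source may report more compounds than this note shows. Statements on the series, on what has been measured and on what is new or still open speak of the compounds shown alone.

Measured so far in a functional assay on SK-MEL-28 cells (Homo sapiens) for cytotoxicity, read by sulforhodamine B assay, with a stated time of 48 h; a lower number here means a stronger inhibitor of growth, a higher number a weaker inhibitor of growth:
compound 1 `ClCc1ccc(Cn2cnc3c(Cl)ncnc32)cc1`: 7940 nM
compound 2 `Nc1nc(Cl)c2ncn(Cc3ccc(CCl)cc3)c2n1`: 18200 nM
compound 3 `ClCc1cccc(Cn2cnc3ncnc(Cl)c32)c1`: 1810 nM

Compound 2 stands highest of the three numbers. Among the measured compounds shown here, its nearest neighbour is compound 1, and the single matched step, a 2.3-fold higher number from compound 1 to compound 2 (0.36 log units; beyond the scatter), shows that adding an amino group to the core of compound 1 raised the number by a modest amount, beyond the scatter. For the measured compounds named here, compound 3 sits furthest from compound 2 and gives the lowest number of the three, but it differs from compound 2 in more than one place, so it offers no single-change step.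

Compound 4 `ClCc1ccc(Cn2cnc3c(Cl)nc(Cl)nc32)cc1` is compound 2 with chloro in place of amino on an aromatic carbon. Going by the values given here, no measured step replaces amino with chloro, so the only bearing evidence is the reverse of the step from compound 1 to compound 2: removing the amino is expected to undo a modest rise, while the effect of the incoming chloro at this place is unknown. A modest fall in the number, a 2.6-fold lower number from compound 2 to compound 4 (0.41 log units; beyond the scatter), is therefore expected, back toward the level of compound 1, with wide uncertainty. Compound 4 is thus estimated at 7000 nM, within 2500 nM to 20000 nM.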

Compound 4, concentration for 50% growth inhibition: 2690 nM
The estimate for compound 4 lay 2.6-fold (0.42 log units) above the measured number; measured number inside the range.
By their numbers in this assay, from the lowest: compounds 3 and 4 (each within the scatter of the next); then compound 1; then compound 2.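

In this assay, the aromatic carbon between two ring nitrogen atoms proves sensitive to the incoming group as well as to the loss of amino: chloro in place of amino gives a 6.8-fold lower number from compound 2 to compound 4 (0.83 log units; beyond the scatter) and is a larger move than removal of amino alone would need to reach the level of compound 1. Chloro in place of hydrogen also counts by itself, giving a 3.0-fold lower number from compound 1 to compound 4 (0.47 log units; beyond the scatter) and setting the order at this position as chloro, then hydrogen, then amino, from the lowest number. Nothing measured here explains this order.

From the compounds shown here alone, whether a methoxy group, a methylamino group or bromo at this carbon would extend the order remains open. Also open, going by these compounds, is whether chloro here would have a similar effect on compound 3.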